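This account rests on a few compounds, and the source may have more. Where it says the series, first, only, none or still open, it means among the compounds named here.

Compound 3 `CC(C)C(c1ccc(-c2ccc3cccc(F)c3c2)[nH]c1=O)C1C(=O)NC(=O)N1C` gives 320 nM in a functional assay on CHO cells for antagonist activity at prostaglandin E2 receptor EP3 subtype (Homo sapiens), read by cAMP accumulation, with a stated time of 30 min (on this read-out lower numbers stand for stronger inhibition and higher numbers for weaker inhibition), the highest of the three numbers shown. Compound 1 `C/C(=C1/OC(=O)NC1=O)C(c1ccc(-c2ccc3cccc(F)c3c2)[nH]c1=O)C(C)C` gives 39 nM and compound 2 `CC(C)(/C=C1\OC(=O)NC1=O)c1ccc(-c2ccc3cccc(F)c3c2)[nH]c1=O` gives 57 nM in this assay; the step of an 8.2-fold higher number from compound 1 to compound 3 (0.91 log units; beyond the scatter) is the only one that bears on a change at this carbon, and both companions sit well below compound 3. Compound 4 `CC(C)C(c1ccc(-c2ccc3cccc(F)c3c2)[nH]c1=O)C1SC(=O)NC1=O` differs from compound 3 by 2,4-dioxo-1,3-thiazolidin-5-yl in place of 3-methyl-2,5-dioxoimidazolidin-4-yl on a saturated chain carbon bound to an aromatic carbon and a saturated chain carbon. Since the measured step shows that the ring on this carbon moves the number by a modest but real amount, and compound 4 keeps the saturated attachment of compound 3, a modest step is expected, more likely downward, as a 2.1-fold lower number from compound 3 to compound 4 (0.33 log units; beyond the scatter). Compound 4 is therefore estimated at 150 nM in this assay, within 50 nM to 500 nM.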

Compound 4, half-maximal inhibitory concentration: 110 nM
Beside the measured number, compound 4's estimate is 1.4-fold (0.13 log units) above it, and the stated range covers the measured number.
By their numbers in this assay, from the lowest: compounds 1, 2 and 4 (each within the scatter of the next, the first and the last beyond it); then compound 3.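

In this assay there is a 2.9-fold lower number from compound 3 to compound 4 (0.46 log units; beyond the scatter) on exchanging 3-methyl-2,5-dioxoimidazolidin-4-yl for 2,4-dioxo-1,3-thiazolidin-5-yl, so the ring alone moves the number on this saturated chain carbon, with the saturated attachment unchanged. Compound 1 still stands apart, with a 2.8-fold higher number from compound 1 to compound 4 (0.45 log units; beyond the scatter) remaining between its group and the new ring. Nothing measured here gives a reason for either step.

The compounds shown leave open whether a ring is needed on this carbon at all, as a carboxylic acid there would tell. They also leave open whether 2,4-dioxo-1,3-thiazolidin-5-yl keeps its advantage with other groups on the shared core.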